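Adding a second trifluoromethyl group to compound 3

The source may hold more compounds than are shown below. What is called first, only, known or untested is meant among the compounds shown, and "the series" means these compounds.

Measured in a functional assay on NCI-H460 cells (Homo sapiens) for inhibition, read by MTT assay, with a stated time of 72 h; a lower number here means a stronger inhibitor, a higher number a weaker inhibitor:
Compound 1 `COc1cc(NC(C)CCCNC(=O)NNC(=O)Nc2ccc(F)cc2)c2ncccc2c1`: > 100000 nM, a limit of the assay
Compound 2 `COc1cc(NC(C)CCCNC(=O)NNC(=O)Nc2ccc(Cl)cc2)c2ncccc2c1`: 63000 nM
Compound 3 `COc1cc(NC(C)CCCNC(=O)NNC(=O)Nc2cccc(C(F)(F)F)c2)c2ncccc2c1`: 20000 nM

Only two of these three results are actual numbers, and compound 3 holds the lower of them at 20000 nM. Compound 2 stands above it, and the step between them is a 3.2-fold lower number from compound 2 to compound 3 (0.50 log units; beyond the scatter). Compound 1 gives only a limit, > 100000 nM.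

Compound 4 `COc1cc(NC(C)CCCNC(=O)NNC(=O)Nc2cc(C(F)(F)F)cc(C(F)(F)F)c2)c2ncccc2c1` has not yet been measured. It differs from compound 3 by one change, trifluoromethyl in place of hydrogen on an aromatic carbon, meta to a trifluoromethyl group: trifluoromethyl in place of hydrogen on an aromatic carbon.

Among the compounds with values here, no measured step adds a second group of this kind, so the evidence is indirect. The closest guides are the two exchanges that lead to compound 3, namely a 3.2-fold lower number from compound 2 to compound 3 (0.50 log units; beyond the scatter) and, measured against a limit, an at least 5.0-fold lower number from compound 1 to compound 3 (0.69 log units; beyond the scatter). The remaining exchange, an at least 1.5-fold lower number from compound 1 to compound 2 (0.20 log units; that floor lies within the scatter), says little. On the strength of the step to compound 3, a further modest move towards a lower number is expected, of about the same size, though it could prove smaller. The expected change is a 2.5-fold lower number from compound 3 to compound 4 (0.40 log units; beyond the scatter). For compound 4 the estimated value is 8000 nM, with an expected range from 2500 nM to 30000 nM.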

Compound 4, half-maximal inhibitory concentration: 18000 nM
Compound 4: the middle estimate sits 2.3-fold (0.35 log units) below what was measured; measured number inside the range.
By their numbers in this assay, from the lowest: compounds 4 and 3 (each within the scatter of the next); then compound 2. At a limit, above all of these: compound 1.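

In this assay, trifluoromethyl in place of hydrogen on an aromatic carbon, meta to a trifluoromethyl group, gives a 1.1-fold lower number from compound 3 to compound 4 (0.05 log units; within the scatter), so compound 3 and compound 4 cannot be told apart in this assay. Within the data shown here, the other compounds showed only one group exchanged for another on the aromatic ring, and a 3.2-fold lower number from compound 2 to compound 3 (0.50 log units; beyond the scatter) showed such an exchange lowering the number beyond the scatter; this result shows that the gain seen there does not repeat when a second trifluoromethyl group enters at this position. No measurement given here bears on why this addition of 4 heavy atoms leaves the number within the scatter.

The compounds shown leave open whether a different group on this same aromatic carbon, such as an amine, a carboxylic acid or a nitrile, would move the number in this assay where a second trifluoromethyl group does not. They also leave open whether a longer chain in the shared core would shift the number for compound 3 and compound 4 alike.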